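This account rests on a few compounds, and the source may have more. Where it says the series, first, only, none or still open, it means among the compounds named here.

In an ADME assay on CEMx174 cells (Homo sapiens) for cytotoxicity (a lower number here means that less compound is tolerated, a higher number that more compound is tolerated), compound 1 `CCCC1=C(C(=O)OCC2CCCCC2)C(c2cccc(O)c2)NC(=O)N1` gives > 10000 nM, which is a limit of the assay and not a number. The cells tolerated compound 1 up to that limit, so no half-maximal concentration could be read for it. Compound 2 `CC(C)C1=C(C(=O)OCC2CCCCC2)C(c2cccc(O)c2)NC(=O)N1` has no number of its own, as its result reads "not determined" (no result reported). For the measured compounds named here, its standing on this measure is therefore open, and no measured step links it to any other compound.

The next compound to be tested is compound 3 `O=C1NC(C2CC2)=C(C(=O)OCC2CCCCC2)C(c2cccc(O)c2)N1`, which keeps the shared core of compound 2. The change cyclopropyl in place of isopropyl on a double-bonded ring carbon puts cyclopropyl in place of isopropyl on a double-bonded ring carbon. Going by the values given here, with no measured step to serve as a guide, no shift beyond the usual scatter is expected in this assay, in either direction. Among the compounds with values here, the only reference is compound 1, whose result of > 10000 nM is again just a limit. The same kind of result, a limit rather than a number, is thought likely for the new compound. Compound 3 is estimated at 20000 nM, with an expected range from 8000 nM to 50000 nM.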

Compound 3, half-maximal cytotoxic concentration: > 10000 nM
Compound 3: only a limit was reported (the forecaster's own chance of this, stated with the estimate: 80%); the middle value lies beyond the limit too.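

In this assay, for the compounds shown here, compound 1 and compound 3 each give only a limit and not a number, so no step between them can be read: the limit of > 10000 nM in this assay, at which 2 of the 3 values shown sit.

The compounds shown leave open whether cyclopropyl in place of propyl shifts the result in this assay at all, and where compound 2 stands.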